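Aryl swap on the shared core: cytotoxicity notes

A few compounds are considered here, and "the series" means these few. Any claim that something is new, unique, unknown or untested is made for them only; others in the source may bear on it.

In an ADME assay on Huh-7 cells (Homo sapiens) for cytotoxicity, read by MTT assay, with a stated time of 48 h (a higher number here means that more compound is tolerated, a lower number that less compound is tolerated), compound 1 `CN(C)CCCCOC(=O)Nc1ccc(Cn2nc(-c3cncnc3)c3ccccc3c2=O)cc1` gives 65300 nM, the highest of the two numbers at hand. Compound 2 `CN(C)CCCCOC(=O)Nc1ccc(Cn2nc(-c3ccc(C#N)cc3)c3ccccc3c2=O)cc1` gives 37000 nM in this assay, and the change between them is a 1.8-fold lower number from compound 1 to compound 2 (0.25 log units; within the scatter), a swap of the aromatic group on the same carbon of the shared core. The unmeasured compound 3 `COc1ccccc1-c1nn(Cc2ccc(NC(=O)OCCCCN(C)C)cc2)c(=O)c2ccccc12` differs from compound 1 in one place: 2-methoxyphenyl in place of pyrimidin-5-yl on an aromatic carbon. For the measured compounds named here, the one measured step that bears on this change is the swap already described; it stayed within the scatter. No other comparison on the shared core is available, and the tolerated concentration appears little affected by the identity of this aromatic group on the two examples seen, so no step beyond the scatter is expected here either. Compound 3 is therefore estimated at 50000 nM in this assay, with a range of 20000 nM to 130000 nM. This estimate means an expected step of a 1.3-fold lower number from compound 1 to compound 3 (0.12 log units; within the scatter).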

Compound 3, half-maximal cytotoxic concentration: 44800 nM
Beside the measured number, compound 3's estimate is 1.1-fold (0.05 log units) above it, and the stated range covers the measured number.
By their numbers in this assay, from the lowest: compounds 2, 3 and 1 (each within the scatter of the next).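

At the aromatic carbon next to the ring nitrogen, the 2-methoxyphenyl group gives a third aromatic substituent to compare in this assay: its entry in place of pyrimidin-5-yl is a 1.5-fold lower number from compound 1 to compound 3 (0.16 log units; within the scatter) and its entry in place of 4-cyanophenyl is a 1.2-fold higher number from compound 2 to compound 3 (0.08 log units; within the scatter) in the same series. The earlier pair covered only a single swap, whereas all three steps among these groups now lie within the scatter, including a group with a ring of carbon only and a methoxy substituent at the position printed as its 2-position. Nothing at hand offers an explanation for this flat result.

As far as these compounds go, whether a saturated amine such as piperidine or a carboxylic acid on the aryl ring at this carbon would stay in the same range remains open. From the compounds shown here alone, all three compounds carry the same dimethylaminobutyl carbamate, so the contribution of that chain also remains open.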